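The source may report more compounds than this note shows. Statements on the series, on what has been measured and on what is new or still open speak of the compounds shown alone.

Measured compounds:
compound 1 `O=C1C(=Cc2ccc(O)cc2)C(=O)N(c2ccc(Cl)cc2)N1c1ccc(Cl)cc1` — 20600 nM in a functional assay on SMMC-7721 cells (Homo sapiens) for cytotoxicity, read by MTT assay, with a stated time of 72 h; on this read-out lower numbers stand for stronger inhibition and higher numbers for weaker inhibition
compound 2 `O=C1C(=Cc2ccco2)C(=O)N(c2ccc(Cl)cc2)N1c1ccc(Cl)cc1` — 19500 nM in this assay

Within the data shown here, on the two numbers so far, compound 1 stands alongside compound 2: the step of a 1.1-fold lower number from compound 1 to compound 2 (0.02 log units; within the scatter) lies within the scatter, so the two are not distinguished. Compound 3 `O=C1C(=C/C=C/c2ccccc2)C(=O)N(c2ccc(Cl)cc2)N1c1ccc(Cl)cc1` has not yet been measured. It differs from compound 1 in one place: 2-phenylethenyl in place of 4-hydroxyphenyl on a double-bonded chain carbon bound to a double-bonded ring carbon. Among the measured compounds shown here, the one measured step that bears on this position is the step of a 1.1-fold lower number from compound 1 to compound 2 (0.02 log units; within the scatter), which exchanges the same group for another and leaves the number essentially unchanged. Nothing in the measured pairs ties the read-out to what sits at this carbon. The expectation for compound 3 is therefore a step of about a 1.1-fold lower number from compound 1 to compound 3 (0.06 log units; within the scatter), no change beyond the scatter. Compound 3 is estimated at 18000 nM in this assay, with a range from 7000 nM to 50000 nM.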

Compound 3, half-maximal inhibitory concentration: 10100 nM
Estimate against measurement, compound 3: 1.8-fold (0.25 log units) above, and the stated range covers the measured number.
By their numbers in this assay, from the lowest: compounds 3, 2 and 1 (each within the scatter of the next, the first and the last beyond it).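

In this assay, among these compounds, 2-phenylethenyl in place of 4-hydroxyphenyl on a double-bonded chain carbon bound to a double-bonded ring carbon gives a 2.0-fold lower number from compound 1 to compound 3 (0.31 log units; beyond the scatter) and is the first step at this position to pass the scatter, though only modestly. Set against furan-2-yl, the same group gives a 1.9-fold lower number from compound 2 to compound 3 (0.29 log units; within the scatter) so compound 3 is not separated from compound 2 and the position shows only a small response, resting on one pair. No measurement on hand accounts for the step between compound 1 and compound 3.

Compound 3 adds a double bond outside aromatic rings and drops the hydroxyl in one change, and the shares of these two differences remain unresolved; an unsubstituted phenyl at this carbon would separate them. As far as these compounds go, how an amine on the phenyl ring or a longer chain of conjugated double bonds would read at this carbon also remains open.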